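This account rests on a few compounds, and the source may have more. Where it says the series, first, only, none or still open, it means among the compounds named here.

Two compounds of the series have numbers in an in vitro assay on HEK-tsA201 cells for antagonist activity at Neuronal acetylcholine receptor; alpha3/beta4 (Homo sapiens), read by fluorescence and calcium flux (on this read-out higher numbers stand for weaker inhibition and lower numbers for stronger inhibition), so far. Compound 1 `C=CCOc1ccc(C(=O)Nc2cccc(C)n2)cc1` gives 31700 nM in this assay. Compound 2 `CCCOc1ccc(C(=O)Nc2cccc(C)n2)cc1` gives 11100 nM in this assay, the lowest of the two numbers. For the measured compounds named here, the single measured step, a 2.9-fold lower number from compound 1 to compound 2 (0.46 log units; beyond the scatter), separates the two and sets compound 2 below compound 1 by more than the scatter.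

Compound 3 `CCCOc1ccc(C(=O)Nc2cccc(Cl)n2)cc1` differs from compound 2 in one place: chloro in place of methyl on an aromatic carbon. This change sits on the aromatic ring bound to the amide nitrogen, next to the ring nitrogen, whereas the measured step from compound 1 to compound 2 concerns the saturated chain on the ether oxygen at the far end of the molecule. Going by the values given here, no measured step therefore bears on the exchange of methyl for chloro, and the two compounds in hand give no indication of direction for it.

On that basis the number for compound 3 is expected to stay close to that of compound 2, with the step of a 1.1-fold lower number from compound 2 to compound 3 (0.05 log units; within the scatter) expected to fall within the scatter. Compound 3 is estimated at 10000 nM in this assay, with a range from 3000 nM to 35000 nM.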

Compound 3, half-maximal inhibitory concentration: > 100000 nM
Compound 3 was reported as a limit; the forecaster's own chance of this, stated with the estimate: 5%; at least 10-fold (1.00 log units) between middle value and limit.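

The aromatic carbon next to the ring nitrogen is not a tolerant place in this assay: chloro in place of methyl there, one heavy atom for one heavy atom with no change in the counts of hydrogen-bond donors and acceptors or in net charge, gives an at least 9.0-fold higher number from compound 2 to compound 3 (0.95 log units; beyond the scatter). Compound 3 stands as a limit, not a number, in this assay: the limit of > 100000 nM in this assay, at which 1 of the 3 values shown sits. Even so, this change on the ring bound to the amide nitrogen is larger in size than the only earlier step, a 2.9-fold lower number from compound 1 to compound 2 (0.46 log units; beyond the scatter), which lay on the chain at the ether oxygen, so the series now has a first reading at this end of the molecule.

Open, going by these compounds, is whether the rise belongs to chloro alone or to any replacement of methyl at this place; hydrogen, fluoro, methoxy or ethyl there would separate those two readings. Also open, on these data alone, is whether a longer chain or a cyclopropylmethyl group on the ether oxygen moves the number further down from compound 2, and whether the chloro step holds with the chain of compound 1.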